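Swapping benzylamino for methyl(propargyl)amino: an expected gain

This account rests on a few compounds, and the source may have more. Where it says the series, first, only, none or still open, it means among the compounds named here.

Measured so far:
compound 1 `c1ccc(CNCc2cn(Cc3ccccc3)c3ccccc23)cc1` gives 244000 nM in an assay on isolated protein for inhibition of Amine oxidase [flavin-containing] A (Rattus norvegicus); on this read-out higher numbers stand for weaker inhibition and lower numbers for stronger inhibition
compound 2 `CC#CCN(C)Cc1cc2cc(O)ccc2n1C` gives 5.7 nM in this assay

Of the compounds shown here, two have been measured, and they sit far apart. Compound 1 has the higher of the two numbers, so it is the weaker inhibitor of the pair, and the gap to compound 2 lies well beyond the usual scatter. The two share no single-point difference, so their values can only be set side by side.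

The next compound, compound 3 `C#CCN(C)Cc1cn(Cc2ccccc2)c2ccccc12`, is compound 1 with one change: methyl(propargyl)amino in place of benzylamino on a saturated chain carbon bound to an aromatic carbon. The benzylamino of compound 1 is replaced by a short chain ending in a triple bond, a motif that also appears, in a closely related form, on compound 2.

For compound 3 a large step toward stronger inhibition is expected, a 120-fold lower number from compound 1 to compound 3 (2.09 log units; beyond the scatter), because compound 2 carries a related alkyne-bearing amine and gives 5.7 nM. Since the core of compound 3 is that of compound 1 and not that of compound 2, the expectation stops well short of the value of compound 2. The estimate for compound 3 is 2000 nM, with a range from 200 nM to 20000 nM.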

Compound 3, inhibition constant: 160000 nM
Compound 3: middle estimate off by 80-fold (1.90 log units), on the low side; measured number outside the range, above it.
By their numbers in this assay, from the lowest: compound 2; then compounds 3 and 1 (each within the scatter of the next).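

At this place, on a saturated chain carbon bound to an aromatic carbon, methyl(propargyl)amino in place of benzylamino gives a 1.5-fold lower number from compound 1 to compound 3 (0.18 log units; within the scatter) in this assay, so on this shared core the two groups cannot be told apart by this read-out. The swap removes a six-membered aromatic ring and a hydrogen-bond donor and brings in a triple bond, and none of this moves the number beyond the scatter. Compound 3 differs from compound 2 in more than one place, so the value of compound 2, 5.7 nM, cannot be credited to its alkyne-bearing amine, and no measurement shown here accounts for the flat step.

Still open, on these data alone, is whether any amine at this place changes the number on this core: dimethylamino, or a longer chain ending in a triple bond, would test that. Among the compounds shown, no single change links compound 2 to compound 3, so which of the features of compound 2 goes with its low number remains unresolved.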